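A few compounds are considered here, and "the series" means these few. Any claim that something is new, unique, unknown or untested is made for them only; others in the source may bear on it.

Working notes on the series, all read in a functional assay on MCF7 cells (Homo sapiens) for antiproliferative activity, read by MTT assay, with a stated time of 72 h; on this read-out higher numbers stand for weaker inhibition and lower numbers for stronger inhibition.

Compound 1 `O=C1COc2ccc(-c3cccc(NS(=O)(=O)c4ccc(F)cc4)c3)cc2N1c1ccccc1` carries a phenyl on the amide-type nitrogen of the shared core. In this assay compound 1 returns only the limit > 40000 nM, not a number. For the measured compounds named here, compound 2 `O=C1COc2ccc(-c3cnc(Cl)c(NS(=O)(=O)c4ccc(F)cc4)c3)cc2N1c1ccc(F)cc1` is the one member of the set with a measured value; in this assay compound 2 gives 32600 nM, a weak result. Compound 3 `O=C1COc2ccc(-c3ccc(O)cc3)cc2N1` has the amide hydrogen in place and a phenol on the other side of the core. In this assay compound 3 also returns only the limit > 40000 nM. Thus compound 3 stands at the ceiling of the measurement, and the same ceiling holds for most of the set: the limit of > 40000 nM in this assay, at which 2 of the 3 values shown sit.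

The step to compound 4 `COc1ccc(N2C(=O)COc3ccc(-c4ccc(O)cc4)cc32)cc1` is 4-methoxyphenyl in place of hydrogen on an amide-type nitrogen in a ring. Going by the values given here, no measured step is available for this change. With compound 1 and compound 3 both at the limit and compound 2 weak, compound 4 is expected to stay weak, with a step from an at least 1.1-fold lower number from compound 3 to compound 4 (0.05 log units; that floor lies within the scatter) that most likely stays within the scatter or remains a limit. The estimate for compound 4 in this assay is 35000 nM, in a range from 8000 nM to 40000 nM.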

Compound 4, half-maximal inhibitory concentration: 17300 nM
For compound 4 the middle estimate is 2.0-fold (0.31 log units) above the measured one; low and high end bracket the measured number.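

In this assay, the series gains its first comparison at a single place, on the amide-type nitrogen in a ring: 4-methoxyphenyl in place of hydrogen gives an at least 2.3-fold lower number from compound 3 to compound 4 (0.36 log units; beyond the scatter). Compound 4 therefore shows that this nitrogen can carry an aromatic substituent without loss of activity, although compound 4 remains weak at 17300 nM. The true size of the step stays unknown because the value of compound 3 is a limit and not a number: the limit of > 40000 nM in this assay, at which 2 of the 4 values shown sit.

The compounds shown leave open whether the change depends on the methoxy group or would follow with an unsubstituted phenyl on the same phenol-bearing core. Going by these compounds, how a methyl group, an aminoethyl chain or a carboxylic acid at this nitrogen would read also remains open.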